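Swapping the ring substituent back: acetyl returns on a pyrazole

The compounds below may be only part of what the source reports. "The series", "measured", "known", "first", "only" and "open" are said of these compounds alone.

Of the compounds shown here, three sharing one core have been tested in a functional assay on MV4-11 cells (Homo sapiens) for antiproliferative activity, with a stated time of 6 days, tested at 1.56 uM; a higher number here means a stronger effect of the compound at the concentration tested, a lower number a weaker effect. Compound 1 `CNC(=O)N1CCCc2ccc(NC(=O)c3cccc(-c4ccn(C(C)=O)n4)c3)cc21` gives 27.6%. Compound 2 `CNC(=O)N1CCCc2ccc(NC(=O)c3cccc(-c4cnn(S(C)(=O)=O)c4)c3)cc21` gives 1.6%, and compound 3 `CNC(=O)N1CCCc2ccc(NC(=O)c3cccc(-c4ccn(S(C)(=O)=O)n4)c3)cc21` gives 4.03%. Among the three numbers, compound 3 sits second, with compound 2 close by and compound 1 well apart.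

Compound 4 `CNC(=O)N1CCCc2ccc(NC(=O)c3cccc(-c4cnn(C(C)=O)c4)c3)cc21` has not been measured yet. It differs from compound 3 in one place: 1-acetyl-1H-pyrazol-4-yl in place of 1-(methylsulfonyl)-1H-pyrazol-3-yl on an aromatic carbon. Among the measured compounds shown here, two measured steps bear on this change. Undoing the first, the swap of methylsulfonyl for acetyl, gave a fall of a number 23.6 percentage points lower from compound 1 to compound 3 (beyond the scatter), so putting acetyl back should raise the number by roughly that much. Moving the attachment point of the pyrazole ring mattered little, as shown by a number 2.4 percentage points higher from compound 2 to compound 3 (within the scatter). Compound 4 is therefore expected to land near compound 1, a rise of about a number 20 percentage points higher from compound 3 to compound 4 (beyond the scatter). The estimated value for compound 4 in this assay is 24%, between 8% and 40%.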

Compound 4, a percentage reported as inhibition, at one concentration (the size of the read-out at that concentration, not a potency): 33.6%
Beside the measured number, compound 4's estimate is 9.6 percentage points below it; the measured number falls inside the stated range.
By their numbers in this assay, from the lowest: compounds 2 and 3 (each within the scatter of the next); then compounds 1 and 4 (each within the scatter of the next).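

In this assay, acetyl in place of methylsulfonyl on the pyrazol-4-yl ring gives a number 32 percentage points higher from compound 2 to compound 4 (beyond the scatter), so the gain seen with acetyl now appears at both attachment points of the pyrazole. Moving the attachment with acetyl kept in place gives a number 6 percentage points higher from compound 1 to compound 4 (within the scatter), while changing the group and the attachment together gives a number 29.6 percentage points higher from compound 3 to compound 4 (beyond the scatter), so among these four compounds the group on the aromatic nitrogen, not the attachment point, separates the numbers. The swap between the two groups reads alike at both attachment points: the same change on two cores in this assay, a number 23.6 percentage points lower (beyond the scatter) from compound 1 to compound 3 and a number 32 percentage points lower (beyond the scatter) from compound 4 to compound 2, 8.4 percentage points apart, within the scatter of two such steps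

The compounds shown leave open how a plain methyl group or a propanoyl group on that aromatic nitrogen would compare with acetyl. They also leave open whether the pyrazole itself matters, since all four compounds carry one.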